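This account rests on a few compounds, and the source may have more. Where it says the series, first, only, none or still open, it means among the compounds named here.

Two compounds share one core and differ only in the aryl group on a carbon with a double bond to nitrogen. Compound 1 `COc1ccccc1-c1nnc(-c2ccc(C(=O)N/N=C/c3ccccc3F)cc2)o1` carries a 2-fluorophenyl there, and in an ADME assay on THP-1 cells (Homo sapiens) for cytotoxicity (on this read-out lower numbers stand for stronger inhibition and higher numbers for weaker inhibition), compound 1 gives 313000 nM. Compound 2 `COc1ccc(/C=N/NC(=O)c2ccc(-c3nnc(-c4ccccc4OC)o3)cc2)cc1O` carries a 3-hydroxy-4-methoxyphenyl instead, and in this assay compound 2 gives 260000 nM. The two values sit within the scatter of each other: a 1.2-fold lower number from compound 1 to compound 2 (0.08 log units; within the scatter). Compound 3 `COc1ccccc1-c1nnc(-c2ccc(C(=O)N/N=C/c3ccccn3)cc2)o1` is not yet measured; it differs from compound 2 in one place: pyridin-2-yl in place of 3-hydroxy-4-methoxyphenyl on a carbon with a double bond to nitrogen. Among the measured compounds shown here, only one measured step bears on this change, the exchange of the aryl group that separates compound 1 from compound 2, and it stayed within the scatter. An aryl exchange at this carbon has therefore so far left this assay essentially unchanged, and a step of a 1.1-fold higher number from compound 2 to compound 3 (0.05 log units; within the scatter) is expected, with no direction beyond the scatter. Compound 3 is thus estimated to give 290000 nM in this assay, in a range from 140000 nM to 600000 nM.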

Compound 3, half-maximal inhibitory concentration: 67000 nM
Estimate against measurement, compound 3: 4.3-fold (0.64 log units) above, outside the stated range (below it).
By their numbers in this assay, from the lowest: compound 3; then compounds 2 and 1 (each within the scatter of the next).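

In this assay the pyridin-2-yl brings a 3.9-fold lower number from compound 2 to compound 3 (0.59 log units; beyond the scatter) and a 4.7-fold lower number from compound 1 to compound 3 (0.67 log units; beyond the scatter) on the carbon with a double bond to nitrogen, so this position can affect the read-out after all. Swapping 2-fluorophenyl for 3-hydroxy-4-methoxyphenyl had moved nothing beyond the scatter, while the step to a ring holding a nitrogen does, and it does so from either compound. A lower number here stands for stronger inhibition, so compound 3 is the most cytotoxic of the three, though all the steps involved are modest.

As far as these compounds go, it remains open whether the nitrogen's place in the ring matters, as pyridin-3-yl or pyridin-4-yl would show, or whether unsubstituted phenyl would behave like compound 3 or like the other two compounds. Nothing measured here gives a reason for the shift.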